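A Second Chloro Group on a Shared Side Chain

This account rests on a few compounds, and the source may have more. Where it says the series, first, only, none or still open, it means among the compounds named here.

Measured compounds:
Compound 1 `CN(C)CCNc1nc(-c2ccc(NC(=O)Nc3ccccc3Cl)cc2)nc2ccsc12` gives 310 nM in a functional assay on HT-29 cells (Homo sapiens) for cytotoxicity, read by MTT assay, with a stated time of 72 h; on this read-out higher numbers stand for weaker inhibition and lower numbers for stronger inhibition.
Compound 2 `CN(C)CCNc1nc(-c2ccc(NC(=O)Nc3ccc(Cl)cc3Cl)cc2)nc2ccsc12` gives 1320 nM in this assay.
Compound 3 `CCN(CC)CCCNc1nc(-c2ccc(NC(=O)Nc3ccccc3Cl)cc2)nc2c(Cl)c(Cl)sc12` gives 410 nM in this assay.

Compound 1 and compound 2 differ in one place only: chloro in place of hydrogen on an aromatic carbon. This single change gave a 4.3-fold higher number from compound 1 to compound 2 (0.63 log units; beyond the scatter), so the second chloro group cost potency in a clear but modest way.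

Compound 3 carries the same (2-chlorophenyl)carbamoyl part as compound 1 but sits on a different core; the difference between the two cores is not broken down here. In this assay compound 3 sits close to compound 1, and the gap between them is within the scatter of repeated measurements.

Compound 4 `CCN(CC)CCCNc1nc(-c2ccc(NC(=O)Nc3ccc(Cl)cc3Cl)cc2)nc2c(Cl)c(Cl)sc12` has not yet been measured. It stands to compound 3 exactly as compound 2 stands to compound 1: chloro in place of hydrogen on an aromatic carbon. The place and the entering group are the same, so this is the same change, made on the core of compound 3 instead of the core of compound 1.

If the effect of this change carries over from one core to the other, compound 4 is expected to show a 4.1-fold higher number from compound 3 to compound 4 (0.62 log units; beyond the scatter), an estimate that rests on the earlier step because a 4.3-fold higher number from compound 1 to compound 2 (0.63 log units; beyond the scatter). Compound 4 is therefore estimated at 1700 nM in this assay, with a likely range from 700 nM to 4200 nM.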

Compound 4, half-maximal inhibitory concentration: 1230 nM
The estimate for compound 4 lay 1.4-fold (0.14 log units) above the measured number; low and high end bracket the measured number.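

In this assay, turning the 2-chlorophenyl group of compound 3 into the 2,4-dichlorophenyl group of compound 4 gave a 3.0-fold higher number from compound 3 to compound 4 (0.48 log units; beyond the scatter), so the added chloro group weakened the effect here just as it did on the other core. The two steps point the same way, and their sizes cannot be told apart: the same change on two cores in this assay, a 4.3-fold higher number (0.63 log units; beyond the scatter) from compound 1 to compound 2 and a 3.0-fold higher number (0.48 log units; beyond the scatter) from compound 3 to compound 4, 1.4-fold (0.15 log units) apart, within the scatter of two such steps. For this one pair of cores, then, the step measured on one core was a fair guide to the step on the other, but two pairs in a single cell assay do not make a general rule, and they do not explain why the added chloro group costs potency or show that the step would hold on a further core.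

The compounds shown leave open whether this loss belongs to chloro itself or would follow any group at this place on the ring, such as a fluoro, a methyl or a methoxy group. They also leave open whether the step would stay the same size with a different end to the side chain, such as a morpholine in place of the open-chain amine, or with a longer chain.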